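The source may report more compounds than this note shows. Statements on the series, on what has been measured and on what is new or still open speak of the compounds shown alone.

Series notes on the shared core. Compound 1 `COc1ccc(Oc2ccc3c(NCCCNCc4cc(F)ccc4OC)ccnc3c2)cc1` carries 4-methoxyphenoxy on an aromatic carbon, compound 2 `COc1cccc(CNCCCNc2ccnc3cc(Oc4ccc(Cl)cc4)ccc23)c1O` carries 4-chlorophenoxy there, and compound 3 `COc1ccc(F)cc1CNCCCNc1ccnc2cc(C3CCCCC3)ccc12` carries cyclohexyl. In an ADME assay for permeability, using PAMPA, with a stated time of 30 min, at pH 7.4 (a lower number here means that the compound crosses the layer more slowly, a higher number that the compound crosses the layer faster), compound 1 gives 317 10^-6 cm/s, compound 2 gives 317 10^-6 cm/s and compound 3 gives 23 10^-6 cm/s. Compound 2 stands level with compound 1, the two together giving the highest numbers of the three, with compound 3 well below. For the measured compounds named here, the single measured step, a 14-fold lower number from compound 1 to compound 3 (1.14 log units; beyond the scatter), concerns the cyclohexyl exchange and not the aryl ether substituent. Compound 4 `COc1ccc(Oc2ccc3c(NCCCNCc4cccc(OC)c4O)ccnc3c2)cc1` arises from compound 2 by methoxy in place of chloro on an aromatic carbon. Going by the values given here, no measured step covers this exchange; compounds 1 and 2, which differ here among other places, give the same number. The step of a 1.1-fold lower number from compound 2 to compound 4 (0.02 log units; within the scatter) is therefore expected to stay within the scatter. Compound 4 is estimated at 300 10^-6 cm/s, with a range from 150 10^-6 cm/s to 600 10^-6 cm/s.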

Compound 4, apparent permeability: 317 10^-6 cm/s
Estimate against measurement, compound 4: 1.1-fold (0.02 log units) below; the measured number falls inside the stated range.
By their numbers in this assay, from the lowest: compound 3; then compounds 1, 2 and 4 (each within the scatter of the next).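

In this assay, for the compounds shown here, methoxy in place of chloro on an aromatic carbon, para to a large group, gives no change at the digits printed from compound 2 to compound 4 (within the scatter) and so reads this exchange alone for the first time. The other exchange, 2-hydroxy-3-methoxyphenyl in place of 5-fluoro-2-methoxyphenyl on a saturated chain carbon bound to an amine nitrogen, gives no change at the digits printed from compound 1 to compound 4 (within the scatter) and also reads singly, so neither place separates these compounds in this assay. Still open, as far as these compounds go, is whether an amine or a carboxylic acid in place of chloro or methoxy on this carbon would hold the same number. No measurement at hand accounts for the result.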